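The source may report more compounds than this note shows. Statements on the series, on what has been measured and on what is new or still open speak of the compounds shown alone.

Measured compounds:
- compound 1, `COc1ccc(SCc2nc3c(Cn4ccnc4C)c(O)ccc3n2C)cc1`, gives 164000 nM
- compound 2, `Cn1c(C[S+]([O-])c2ccccc2)nc2c(Cn3ccnc3)c(O)ccc21`, gives 557000 nM
- compound 3, `Cc1ccc2c(nc(CCc3ccc(F)cc3)n2C)c1Cn1ccnc1`, gives 80100 nM

These three compounds were tested in an ADME assay on HepG2 2.2.15 cells (Homo sapiens) for cytotoxicity, with a stated time of 9 days; a lower number here means that less compound is tolerated, a higher number that more compound is tolerated. Among them compound 2 stands highest: its nearest neighbour is compound 1, whose value is beyond the scatter lower, and the furthest is compound 3, whose value is further still below it. Compound 4, `Cn1c(CS(=O)(=O)c2ccccc2)nc2c(Cn3ccnc3)c(O)ccc21`, has not yet been measured. It differs from compound 2 in one place: a group of 9 heavy atoms (6 carbon, 2 oxygen, 1 sulfur; one six-membered aromatic ring of carbon only) in place of a group of 8 heavy atoms (6 carbon, 1 oxygen, 1 sulfur; one six-membered aromatic ring of carbon only), on a saturated chain carbon bound to an aromatic carbon. Among the measured compounds shown here, no step between two measured compounds resembles this change, so the expectation rests only on compound 2. The change keeps the same ring and the same chain carbon, and the shared core is untouched, so the step in this assay from compound 2 to compound 4 is expected to be small, a 1.1-fold lower number from compound 2 to compound 4 (0.05 log units; within the scatter), with no direction beyond the scatter. For compound 4 the expected result in this assay is therefore 500000 nM, within a range from 200000 nM to 1200000 nM.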

Compound 4, half-maximal cytotoxic concentration: 623000 nM
Compound 4: the middle estimate sits 1.2-fold (0.10 log units) below what was measured; the range from low to high includes it.
By their numbers in this assay, from the lowest: compound 3; then compound 1; then compounds 2 and 4 (each within the scatter of the next).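

In this assay, phenylsulfonyl in place of the group with one oxygen fewer, on a saturated chain carbon bound to an aromatic carbon, gives a 1.1-fold higher number from compound 2 to compound 4 (0.05 log units; within the scatter). This is the only pair shown that differs in one place, and it shows that at this position the number of oxygens on the sulfur can change without any readable shift in how much compound the cells tolerate. No measurement at hand says why the change leaves the number in place.

Compound 1 also carries a sulfur at this chain carbon, but it differs from compound 2 and compound 4 in more than one place, so the effect of having no oxygen on that sulfur cannot be read. The compounds shown also leave open whether a different group here, such as an amine or a carboxylic acid, would move the number beyond the scatter.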